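A few compounds are considered here, and "the series" means these few. Any claim that something is new, unique, unknown or untested is made for them only; others in the source may bear on it.

Compound 1, `CN(C)C(=S)N/N=C/c1ccc2ccccc2n1`, gives 90 nM in a functional assay on HeLa cells (Homo sapiens) for antiproliferative activity, read by sulforhodamine B assay, with a stated time of 72 h; on this read-out higher numbers stand for weaker inhibition and lower numbers for stronger inhibition. Compound 2, `NC(=S)N/N=C/c1ccc2ccccc2n1`, differs from it by one change, (amino in place of dimethylamino on a thiocarbonyl carbon), and in this assay compound 2 gives 960 nM; the step is an 11-fold higher number from compound 1 to compound 2 (1.03 log units; beyond the scatter). Compound 3, `CN(C)C(=S)N/N=C/c1cnc2ccccc2n1`, carries the same dimethylamino thiocarbonyl end as compound 1 on a different core; how the two cores differ is not broken down here. In this assay compound 3 gives 750 nM, a number close to that of compound 2, while compound 1 stands well apart from both.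

Compound 4, `NC(=S)N/N=C/c1cnc2ccccc2n1`, has not yet been measured. It is related to compound 3 by the same change that relates compound 2 to compound 1: amino in place of dimethylamino on a thiocarbonyl carbon. Since that change, made once so far, produced a large step from compound 1 to compound 2, a step of the same direction and broadly the same size is expected from compound 3 to compound 4, namely an 8.0-fold higher number from compound 3 to compound 4 (0.90 log units; beyond the scatter). On this basis compound 4 is estimated to give about 6000 nM in this assay, with a plausible range from 1500 nM to 25000 nM.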

Compound 4, half-maximal inhibitory concentration: > 100000 nM
Compound 4 gave a limit, no number (the forecaster's own chance of this, stated with the estimate: 10%); middle value at least 16-fold (1.22 log units) away from the limit.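

Going from dimethylamino to amino on the thiocarbonyl carbon raises the number in this assay on both cores, so the direction of the change carries over, and the new step is an at least 130-fold higher number from compound 3 to compound 4 (2.12 log units; beyond the scatter). Among the compounds shown here, with only two cores to compare, no rule for a further core follows, but the size of the step does not carry over from one core to the other: the same change on two cores in this assay, an 11-fold higher number (1.03 log units; beyond the scatter) from compound 1 to compound 2 and an at least 130-fold higher number (2.12 log units; beyond the scatter) from compound 3 to compound 4, at least 12-fold (1.09 log units) apart, beyond the scatter of two such steps. On these data alone, compound 4 gives > 100000 nM, a limit of the assay and not a number, so the full size of its step stays unknown: the limit of > 100000 nM in this assay, at which 1 of the 4 values shown sits.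

The compounds shown leave open where methylamino, or a cyclic amine such as morpholine, on the thiocarbonyl carbon would fall on either core, and so whether the number rises gradually or abruptly as the methyl groups are lost. They also leave open how the same change behaves on any other core, and what lies behind the gap between the two steps.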